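A few compounds are considered here, and "the series" means these few. Any claim that something is new, unique, unknown or untested is made for them only; others in the source may bear on it.

The compounds share one core and differ only in a single substituent on the six-membered aromatic ring of carbon only. Compound 1 `CCc1cnc(N2CCC(c3nc(COc4ccc(/C=C5\CC(=O)NC5=O)cc4F)cs3)CC2)nc1` carries a fluoro there; in a functional assay on cells for agonist activity at Glucose-dependent insulinotropic receptor (Homo sapiens), read by a luciferase reporter, with a stated time of 6 h (on this read-out lower numbers stand for an effect already at smaller amounts and higher numbers for an effect only at larger amounts of compound), compound 1 gives 49 nM. Compound 2 `CC(C)(C)OC(=O)N1CCC(c2nc(COc3ccc(/C=C4\CC(=O)NC4=O)cc3)cs2)CC1` has a different end group, and in this assay compound 2 gives "not determined" (no result reported). Compound 3 `CCc1cnc(N2CCC(c3nc(COc4ccc(/C=C5\CC(=O)NC5=O)cc4)cs3)CC2)nc1` bears hydrogen at that ring position, and in this assay compound 3 gives 182 nM. Among the two numbers available, compound 3 stands at the higher one; the only neighbour is compound 1, and the step of a 3.7-fold higher number from compound 1 to compound 3 (0.57 log units; beyond the scatter) separates them.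

Compound 4 `CCc1cnc(N2CCC(c3nc(COc4ccc(/C=C5\CC(=O)NC5=O)cc4C)cs3)CC2)nc1` is the next step from compound 3: methyl in place of hydrogen on an aromatic carbon, with the methyl placed ortho to a large group and meta to a group of 8 heavy atoms. Among the measured compounds shown here, only the one measured step bears on it, and it shows that a small substituent at this very position moves the number modestly. Methyl is a different group from fluoro, so the direction is uncertain, but a change of similar size in either direction is the plausible outcome, with a slight lean toward a lower number. The step of a 1.5-fold lower number from compound 3 to compound 4 (0.18 log units; within the scatter) is therefore the expected one for compound 4. Compound 4 is estimated to give 120 nM in this assay, with a range from 40 nM to 400 nM.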

Compound 4, half-maximal effective concentration: 18 nM
Estimate against measurement, compound 4: 6.7-fold (0.82 log units) above; the whole stated range lies above it.
By their numbers in this assay, from the lowest: compound 4; then compound 1; then compound 3.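

At this ring position, on the six-membered aromatic ring of carbon only, the single added carbon of the methyl group does more than the earlier pair could suggest: in this assay, a 10-fold lower number from compound 3 to compound 4 (1.00 log units; beyond the scatter), which makes this the largest step among the compounds shown. The step also separates the two small substituents, since a 2.7-fold lower number from compound 1 to compound 4 (0.43 log units; beyond the scatter), so methyl and fluoro are not interchangeable here, although the printed values show both giving a lower number than the hydrogen of compound 3. Nothing available on these compounds explains why methyl gives the lower number of the two.

The compounds shown leave open whether the trend continues beyond a single carbon at this position, as a longer chain such as ethyl, a methoxy group, a chlorine atom or a trifluoromethyl group could show in either direction. They also leave open whether the methyl step holds with another end group on the shared core, since compound 2 gives no number that could serve as a starting point for such a comparison.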